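Furan-2-yl in place of 3-cyanophenyl on the shared core

The compounds below may be only part of what the source reports. "The series", "measured", "known", "first", "only" and "open" are said of these compounds alone.

Measured so far in an assay on CHO cells for displacement of a labelled ligand from adenosine receptor A3 (Homo sapiens), read by scintillation counting, with a stated time of 3 h; on this read-out higher numbers stand for weaker inhibition and lower numbers for stronger inhibition:
compound 1 `Cc1nc(N)c2nc(-c3ccccc3)sc2n1` gives 2660 nM
compound 2 `COc1cccc(-c2nc(N)c3nc(-c4ccccc4)sc3n2)c1` gives 35.6 nM
compound 3 `N#Cc1cccc(-c2nc(N)c3nc(-c4ccccc4)sc3n2)c1` gives 247 nM

Compound 3 sits second highest of the three numbers in this assay: a 6.9-fold higher number from compound 2 to compound 3 (0.84 log units; beyond the scatter), while an 11-fold lower number from compound 1 to compound 3 (1.03 log units; beyond the scatter). Compound 4 `Nc1nc(-c2ccco2)nc2sc(-c3ccccc3)nc12` differs from compound 3 in one place: furan-2-yl in place of 3-cyanophenyl on an aromatic carbon. Among the compounds with values here, no measured step swaps one aromatic ring for another here; the steps that bear on it are a 75-fold lower number from compound 1 to compound 2 (1.87 log units; beyond the scatter) and an 11-fold lower number from compound 1 to compound 3 (1.03 log units; beyond the scatter), both showing that an aromatic ring at this position gives a far lower number than methyl, and a 6.9-fold higher number from compound 2 to compound 3 (0.84 log units; beyond the scatter), showing that the ring itself matters modestly. A small aromatic ring is therefore expected to keep compound 4 in the range of compound 2 and compound 3, with a modest step in this assay expected: a 2.5-fold lower number from compound 3 to compound 4 (0.39 log units; beyond the scatter). Compound 4 is estimated at 100 nM, range 20 nM to 600 nM.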

Compound 4, inhibition constant: 2.8 nM
Compound 4: the middle estimate sits 36-fold (1.55 log units) above what was measured; measured number below the stated range.
By their numbers in this assay, from the lowest: compound 4; then compound 2; then compound 3; then compound 1.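

In this assay, the furan-2-yl ring on this aromatic carbon between two ring nitrogen atoms gives an 88-fold lower number from compound 3 to compound 4 (1.95 log units; beyond the scatter) and a 13-fold lower number from compound 2 to compound 4 (1.10 log units; beyond the scatter), so changing the ring moves the number further than exchanging methoxy for cyano, a 6.9-fold higher number from compound 2 to compound 3 (0.84 log units; beyond the scatter). Against methyl the step reaches a 950-fold lower number from compound 1 to compound 4 (2.98 log units; beyond the scatter), larger than the step to either substituted phenyl. No supporting data bear on the origin of this result. Still open, as far as these compounds go, is whether thiophen-2-yl or unsubstituted phenyl would match compound 4, which would show whether the ring oxygen or the ring size matters.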